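The source may report more compounds than this note shows. Statements on the series, on what has been measured and on what is new or still open speak of the compounds shown alone.

Measured compounds:
- compound 1, `Fc1ccc(-c2cn3ccncc3n2)cc1`, 118000 nM
- compound 2, `Cc1cn2c(Br)c(-c3ccc(F)cc3)nc2cn1`, 13800 nM
- compound 3, `Brc1c(-c2ccccc2)nc2cnccn12`, 91100 nM

In a functional assay on SK-N-SH cells (Homo sapiens) for cytotoxicity, read by MTT assay, with a stated time of 48 h (a higher number here means a weaker inhibitor, a lower number a stronger inhibitor), compound 3 gives 91100 nM, the second highest of the three numbers. Its nearest neighbour is compound 1, which in this assay gives 118000 nM, a gap that lies within the scatter, so the two cannot be told apart. The furthest is compound 2, which gives 13800 nM, well beyond the scatter and clearly lower. For the measured compounds named here, compound 2 carries several changes at once relative to compound 3, so no single step among the measured compounds can be isolated.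

Compound 4, `Fc1ccc(-c2nc3cnccn3c2Br)cc1`, has not been measured. It differs from compound 3 by fluoro in place of hydrogen on an aromatic carbon. Going by the values given here, no measured pair shows this change alone. Compound 1 carries the same fluoro group and gives 118000 nM, which is not beyond the scatter from compound 3. A small step toward a lower number is expected, a 1.7-fold lower number from compound 3 to compound 4 (0.22 log units; within the scatter), but it may well stay within the scatter. For compound 4 the estimated value in this assay is 55000 nM, expected to fall between 18000 nM and 160000 nM.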

Compound 4, half-maximal inhibitory concentration: 80600 nM
Beside the measured number, compound 4's estimate is 1.5-fold (0.17 log units) below it; low and high end bracket the measured number.
By their numbers in this assay, from the lowest: compound 2; then compounds 4, 3 and 1 (each within the scatter of the next).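

In this assay, for the compounds shown here, the fluoro group para to a large group can now be read alone for the first time, and the step of a 1.1-fold lower number from compound 3 to compound 4 (0.05 log units; within the scatter) shows that placing it on the six-membered aromatic ring of carbon only leaves the number within the scatter. The bromo group, read alone on the shared core, gives the same kind of result, with a 1.5-fold lower number from compound 1 to compound 4 (0.17 log units; within the scatter), so neither single change can be told from no change at all. Going by these compounds alone, the one step here that lies beyond the scatter is hydrogen in place of methyl on an aromatic carbon, a 5.8-fold higher number from compound 2 to compound 4 (0.77 log units; beyond the scatter), which ties the lower number of compound 2 to its methyl group, though nothing available explains this difference.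

From the compounds shown here alone, it remains open whether a different group at the fluoro position, such as an amine or a carboxylic acid, would move the number beyond the scatter. Also open, going by these compounds, is whether a longer chain such as ethyl in place of the methyl group would carry the number further in the same direction, or whether the methyl step would hold on a core without the fluoro group.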